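From hydroxyamino to methoxyamino on the chloro compound

The source may hold more compounds than are shown below. What is called first, only, known or untested is meant among the compounds shown, and "the series" means these compounds.

Measured so far in an ADME assay on MT4 cells (Homo sapiens) for cytotoxicity, read by spectrophotometry, with a stated time of 5 days; on this read-out lower numbers stand for higher toxicity in this test and higher numbers for lower toxicity in this test
- compound 1 `CONC(=S)N/N=C1\C(=O)N(CN2CCN(c3ccccc3)CC2)c2ccc(F)cc21` gives 227000 nM
- compound 2 `O=C1/C(=N\NC(=S)NO)c2cc(Cl)ccc2N1CN1CCN(c2ccccc2)CC1` gives 273000 nM
- compound 3 `O=C1/C(=N\NC(=S)NO)c2cc(F)ccc2N1CN1CCN(c2ccccc2)CC1` gives 251000 nM

Compound 2 (273000 nM) stands level with the other two compounds. Its gaps to both lie within the scatter, so no order among the three can be read.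

Compound 4 `CONC(=S)N/N=C1\C(=O)N(CN2CCN(c3ccccc3)CC2)c2ccc(Cl)cc21` has not been measured. Its change from compound 2 is hydroxyamino to methoxyamino (methyl in place of hydrogen on an oxygen), that is, methyl in place of hydrogen on an oxygen.

Among the compounds with values here, two measured steps bear on this. The same swap, run the other way on the fluoro compounds, gave a small step (a 1.1-fold higher number from compound 1 to compound 3 (0.04 log units; within the scatter)). Fluoro in place of chloro on an aromatic carbon also gave a small step (a 1.1-fold lower number from compound 2 to compound 3 (0.04 log units; within the scatter)), and this links those fluoro compounds to compound 2. Neither step leaves the scatter, so in this assay no step beyond the scatter is expected and no direction can be called. Within the data shown here, no measured pair shows how the swap behaves on a chloro compound, so carrying it over is an assumption.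

The expected outcome is a step within the scatter (a 1.1-fold lower number from compound 2 to compound 4 (0.04 log units; within the scatter)). Compound 4 is estimated at 247000 nM (expected range from 150000 nM to 400000 nM).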

Compound 4, half-maximal cytotoxic concentration: 267000 nM
Compound 4: the middle estimate sits 1.1-fold (0.03 log units) below what was measured; low and high end bracket the measured number.
By their numbers in this assay, from the lowest: compounds 1, 3, 4 and 2 (each within the scatter of the next).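

In this assay, methyl in place of hydrogen on the oxygen of the chloro compound gives a 1.0-fold lower number from compound 2 to compound 4 (0.01 log units; within the scatter), so this change can now be read on a chloro compound and not only on the fluoro pair. On an oxygen whose other neighbour is an amide-type nitrogen, the change from hydroxyamino to methoxyamino behaves alike in both settings: the same change on two cores in this assay, a 1.1-fold higher number (0.04 log units; within the scatter) from compound 1 to compound 3 and a 1.0-fold higher number (0.01 log units; within the scatter) from compound 4 to compound 2, 1.1-fold (0.03 log units) apart, within the scatter of two such steps

The four compounds also give a second reading of the halogen change, this time among the methoxyamino compounds, where chloro in place of fluoro gives a 1.2-fold higher number from compound 1 to compound 4 (0.07 log units; within the scatter), and this agrees with the reading among the hydroxyamino compounds: the same change on two cores in this assay, a 1.1-fold lower number (0.04 log units; within the scatter) from compound 2 to compound 3 and a 1.2-fold lower number (0.07 log units; within the scatter) from compound 4 to compound 1, 1.1-fold (0.03 log units) apart, within the scatter of two such steps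

Across these four compounds, neither change moves the number beyond the scatter, and no compound goes against this. They leave open whether a larger group on that oxygen, such as ethyl or a longer chain, would stay level too, and whether an amine or a carboxylic acid in place of the halogen on the aromatic carbon would do the same.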